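The source may report more compounds than this note shows. Statements on the series, on what has been measured and on what is new or still open speak of the compounds shown alone.

Measured compounds:
compound 1 `O=C1C(=O)N(CCCCCn2cc(COc3cc(=O)oc4ccccc34)nn2)c2ccc(Br)cc21`: 52%
compound 2 `COc1ccc2c(c1)C(=O)C(=O)N2CCCn1cc(COc2cc(=O)oc3ccccc23)nn1`: 56%
compound 3 `O=C1C(=O)N(CCCn2cc(COc3cc(=O)oc4ccccc34)nn2)c2ccc(F)cc21`: 86%

All three numbers come from a functional assay on THP-1 cells (Homo sapiens) for inhibition, read by sulforhodamine B assay, with a stated time of 48 h, tested at 50 uM; a lower number here means less inhibition of growth, a higher number more inhibition of growth at the concentration tested. Compound 3 stands highest of the three in this assay with 86%; the nearest is compound 2 with 56%, the furthest is compound 1 with 52%, and both gaps lie beyond the scatter. Within the data shown here, one measured step bears on the change considered here: a number 30 percentage points higher from compound 2 to compound 3 (beyond the scatter), fluoro in place of methoxy on an aromatic carbon. Compound 4 `O=C1C(=O)N(CCCn2cc(COc3cc(=O)oc4ccccc34)nn2)c2ccc([N+](=O)[O-])cc21` is compound 3 with the change (nitro in place of fluoro on an aromatic carbon). Among the measured compounds shown here, no measured pair shows nitro on that aromatic carbon, so the step from compound 2 to compound 3 says only that the group there can move the number well beyond the scatter; the direction from fluoro to nitro is not fixed by the data. A modest step either way, or none beyond the scatter, is possible, and the expectation sits a little under compound 3, as compound 3 already stands at 86%. For compound 4 in this assay the estimate is 75%, range 50% to 95%, meaning an expected step of a number 11 percentage points lower from compound 3 to compound 4 (beyond the scatter).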

Compound 4, percent growth inhibition at one concentration: 60%
Beside the measured number, compound 4's estimate is 15 percentage points above it; the range from low to high includes it.
By their numbers in this assay, from the lowest: compounds 1, 2 and 4 (each within the scatter of the next); then compound 3.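

In this assay, a number 26 percentage points lower from compound 3 to compound 4 (beyond the scatter), which fixes the direction of the change from fluoro to nitro on this aromatic carbon, a direction that the earlier step from methoxy to fluoro left undetermined. Against that, a number 4 percentage points higher from compound 2 to compound 4 (within the scatter), so nitro and methoxy are not separated at this position, and among these three groups, with the rest of the structure held constant, only fluoro stands apart, with steps beyond the scatter to both others. No measurement at hand accounts for this difference.

Going by these compounds, whether an amine, a carboxylic acid or a chloro group on this carbon would group with fluoro or with nitro and methoxy remains open. On these data alone, compound 1 differs from compound 3 in both its chain and its aromatic group, so the separate contribution of chain length at this position also remains open.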